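The compounds below may be only part of what the source reports. "The series", "measured", "known", "first", "only" and "open" are said of these compounds alone.

Measured so far in a functional assay on HUVEC cells (Homo sapiens); a lower number here means that less compound is needed, a higher number that more compound is needed for the effect:
Compound 1 `Cc1c(O)c(C)c2c(c1O)C(=O)CC(c1cccc(O)c1)O2`: > 20000 nM (a limit)
Compound 2 `Cc1c(O)c(C)c2c(c1O)C(=O)CC(c1ccccc1Cl)O2`: > 20000 nM (a limit)

Compound 2 has no number to its name. In this assay compound 2 gives > 20000 nM, which is a limit of the assay. Compound 1 also gives only a limit, > 20000 nM. Among the compounds with values here, the series so far therefore rests on (the limit of > 20000 nM in this assay, at which 2 of the 2 values shown sit).

Compound 3 `Cc1c(O)c(C)c2c(c1O)C(=O)CC(c1ccco1)O2` carries furan-2-yl in place of 2-chlorophenyl on a saturated ring carbon.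

Within the data shown here, only one measured step bears on this change, a step that the two limits leave unreadable from compound 1 to compound 2. It offers no size to carry over and no direction, so no step beyond the scatter is expected in this assay, and a further limit is the likeliest report. The expected change is a number no higher from compound 2 to compound 3 (the limit leaves the size open). The estimated value for compound 3 is 20000 nM, with an expected range from 6000 nM to 50000 nM.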

Compound 3, half-maximal effective concentration: > 20000 nM
Compound 3: only a limit was reported (the forecaster's own chance of this, stated with the estimate: 70%); the middle value lies on the limit itself.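

In this assay compound 3 gives > 20000 nM, which is a limit. No step from compound 1 or compound 2 to compound 3 can be read, since all three compounds share this result: the limit of > 20000 nM in this assay, at which 3 of the 3 values shown sit.

The compounds shown leave open whether any group at this saturated ring carbon gives a measurable value.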